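Replacing methyl with trifluoromethyl on a saturated ring carbon

The source may report more compounds than this note shows. Statements on the series, on what has been measured and on what is new or still open speak of the compounds shown alone.

In a functional assay (aorta) with Rattus norvegicus as the target (a lower number here means that less compound is needed, a higher number that more compound is needed for the effect), compound 1 `C/N=C(/S)C1=CC(C(F)(F)F)(C(F)(F)F)Oc2ccc([N+](=O)[O-])cc21` gives 0.631 nM and compound 2 `CC1(C(F)(F)F)C=C(C(=O)NCCC#N)c2cc([N+](=O)[O-])ccc2O1` gives 0.692 nM as its half-maximal effective concentration. Compound 2 therefore stands within the scatter of compound 1, and the two numbers cannot be ranked.

Compound 3 `N#CCCNC(=O)C1=CC(C(F)(F)F)(C(F)(F)F)Oc2ccc([N+](=O)[O-])cc21` keeps the (2-cyanoethyl)carbamoyl group of compound 2 and takes trifluoromethyl in place of methyl on a saturated ring carbon next to the ring oxygen, the change trifluoromethyl in place of methyl on a saturated ring carbon being the only difference between them. Among the measured compounds shown here, no two measured compounds differ in one place only, so this step has no direct precedent. Compound 1 also carries trifluoromethyl on that ring carbon; it gives 0.631 nM in this assay and lies within the scatter of compound 2 despite its other differences. On that evidence, no shift beyond the scatter is expected in either direction. The expected step of a 1.0-fold higher number from compound 2 to compound 3 (0.00 log units; within the scatter) is an estimate with no firm direction. Compound 3 is estimated at 0.7 nM with a range of 0.15 nM to 3 nM for its measurement.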

Compound 3, half-maximal effective concentration: 0.49 nM
For compound 3 the middle estimate is 1.4-fold (0.15 log units) above the measured one; measured number inside the range.
By their numbers in this assay, from the lowest: compounds 3, 1 and 2 (each within the scatter of the next).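

The methyl-to-trifluoromethyl change on this saturated ring carbon can now be read directly in this assay (a 1.4-fold lower number from compound 2 to compound 3 (0.15 log units; within the scatter)), so with the (2-cyanoethyl)carbamoyl group held constant, the number does not move beyond the scatter with either group on that carbon. Among the compounds shown here, compound 3 also gives the first one-place reading on the double-bonded ring carbon (a 1.3-fold lower number from compound 1 to compound 3 (0.11 log units; within the scatter)), and with trifluoromethyl kept on the saturated ring carbon, the group of 7 heavy atoms and the group of 4 heavy atoms cannot be told apart in this measurement. No other measurement offered here bears on the cause of these results.

The compounds shown leave open whether this saturated ring carbon would stay within the scatter with a hydrogen, an ethyl group or a longer chain in place of methyl or trifluoromethyl. They also leave open whether an amine or a carboxylic acid on the double-bonded ring carbon would give a number that still lies within the scatter of the three compounds shown.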